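From Chloro to Fluoro: Expected Cytotoxicity of Compound 4

The compounds below may be only part of what the source reports. "The series", "measured", "known", "first", "only" and "open" are said of these compounds alone.

In a functional assay on DLD-1 cells (Homo sapiens) for cytotoxicity, read by colorimetric assay and MTT assay, with a stated time of 3 days, tested at 1 uM (on this read-out higher numbers stand for a weaker effect at the one concentration tested and lower numbers for a stronger effect), compound 3 `O=C1COc2ccc(-c3nn(-c4ccc(Cl)cc4)cc3-c3ccccc3)cc2N1` gives 61.9%, the lowest number among the three measured compounds. Compound 1 `COc1ccc(-n2cc(-c3ccccc3)c(-c3ccc4c(c3)NC(=O)CO4)n2)cc1` gives 92.2% and compound 2 `Cc1ccccc1-n1cc(-c2ccccc2)c(-c2ccc3c(c2)NC(=O)CO3)n1` gives 92.2%. The steps of a number 30.3 percentage points lower from compound 1 to compound 3 (beyond the scatter) and a number 30.3 percentage points lower from compound 2 to compound 3 (beyond the scatter) show that bringing in the chloro group lowered the number strongly, while the step of no change at the digits printed from compound 1 to compound 2 (within the scatter) shows that two other groups gave no difference. Compound 4 `O=C1COc2ccc(-c3nn(-c4ccc(F)cc4)cc3-c3ccccc3)cc2N1` differs from compound 3 by fluoro in place of chloro on an aromatic carbon. Both the leaving and the entering group are halogens, so this change is smaller than either measured step, and the number is expected to rise only modestly, an estimated step of a number 12.1 percentage points higher from compound 3 to compound 4 (beyond the scatter). Compound 4 is therefore estimated at 74%, within a range from 58% to 92%.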

Compound 4, a percentage reported as activity, at one concentration (the size of the read-out at that concentration, not a potency): 64.4%
Compound 4: the middle estimate sits 9.6 percentage points above what was measured; low and high end bracket the measured number.
By their numbers in this assay, from the lowest: compounds 3 and 4 (each within the scatter of the next); then compounds 1 and 2 (each within the scatter of the next).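

In this assay, fluoro in place of chloro, para to a large group, gives a number 2.5 percentage points higher from compound 3 to compound 4 (within the scatter), so these two halogens cannot be told apart at this position. Fluoro also keeps the gap to the other groups, with a number 27.8 percentage points lower from compound 1 to compound 4 (beyond the scatter) and a number 27.8 percentage points lower from compound 2 to compound 4 (beyond the scatter), so the lower number is not tied to chloro alone. No measurement offered here explains this. Still open, from the compounds shown here alone, is whether bromo would behave like these two halogens, and whether an amine or a carboxylic acid at this position would keep the number low.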